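Fluoro in place of hydroxy at the top of the range

This account rests on a few compounds, and the source may have more. Where it says the series, first, only, none or still open, it means among the compounds named here.

Compound 1 (`O=C(/C=C/c1ccc2c(c1)B(O)OC2)c1ccc([N+](=O)[O-])cc1`) gives > 10 ug/mL in an ADME assay on L929 cells (Mus musculus) for cytotoxicity, read by resazurin assay, with a stated time of 72 h (a lower number here means a stronger inhibitor, a higher number a weaker inhibitor), a limit of the assay and not a number. Compound 2 (`O=C(/C=C/c1ccc2c(c1)B(O)OC2)c1ccc(O)cc1`) gives > 10 ug/mL, again only a limit. Neither compound has a numerical value, and the measured data amount to the limit of > 10 ug/mL in this assay, at which 2 of the 2 values shown sit.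

Compound 3 (`O=C(/C=C/c1ccc2c(c1)B(O)OC2)c1ccc(F)cc1`) carries fluoro in place of hydroxy on an aromatic carbon, para to a large group: fluoro in place of hydroxy on an aromatic carbon.

Going by the values given here, the only measured step, a step that the two limits leave unreadable from compound 1 to compound 2, has no readable size and gives nothing to carry over, so no step beyond the scatter is expected in this assay, and no direction can be assigned. The estimated step is a step that the limit leaves unreadable from compound 2 to compound 3, a nominal figure. Compound 3 is expected at 20 ug/mL (estimated range 10 ug/mL to 60 ug/mL), most probably reported as a limit again.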

Compound 3, half-maximal inhibitory concentration: > 10 ug/mL
Compound 3 gave a limit, no number; the forecaster's own chance of this, stated with the estimate: 80%; the middle value lies beyond the limit too.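

No step can be read among compound 1, compound 2 and compound 3 in this assay, since each gives only a limit and not a number: the limit of > 10 ug/mL in this assay, at which 3 of the 3 values shown sit.

The compounds shown leave open whether nitro, hydroxy and fluoro differ at all in this assay.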